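Lengthening the side chain of compound 2

This account rests on a few compounds, and the source may have more. Where it says the series, first, only, none or still open, it means among the compounds named here.

Going by the values given here, in an ADME assay for permeability, using PAMPA, with a stated time of 30 min, tested at 10 uM (a higher number here means that the compound crosses the layer faster, a lower number that the compound crosses the layer more slowly), compound 2 (`COCCOc1cc2c(-n3nc(-c4ccccn4)nc3N)ncnc2cc1OC`) gives 196 10^-6 cm/s, the higher of the two numbers measured so far. Among the compounds with values here, the only other measured compound, compound 1 (`COCCOc1cc2ncnc(-n3nc(-c4ccccn4)nc3N)c2cc1OCCOC`), gives 16.6 10^-6 cm/s. Compound 3 (`COc1cc2ncnc(-n3nc(-c4ccccn4)nc3N)c2cc1OCCCNC(=O)OC(C)C`) has not yet been measured. It differs from compound 2 as follows: ((isopropoxycarbonyl)amino)methyl in place of methoxy on a saturated chain carbon, two bonds along the chain from an oxygen on an aromatic ring. Put simply, ((isopropoxycarbonyl)amino)methyl stands in place of methoxy on a saturated chain carbon, two bonds along the chain from an oxygen on an aromatic ring.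

Within the data shown here, one measured step bears on this change, as it also concerns a chain on an oxygen on an aromatic ring. With hydrogen in place of methoxymethyl, the number rises by a 12-fold higher number from compound 1 to compound 2 (1.07 log units; beyond the scatter), a large step beyond the scatter. Read in reverse, the larger chain goes with the lower number. Among the measured compounds shown here, this is only a single pair, however, and the group entering here is a different one, so its size carries over only loosely. The expected change in this assay is a drop, with an estimated step of a 4.9-fold lower number from compound 2 to compound 3 (0.69 log units; beyond the scatter). For compound 3 the estimated value is 40 10^-6 cm/s, with an expected range from 10 10^-6 cm/s to 140 10^-6 cm/s.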

Compound 3, apparent permeability: 433 10^-6 cm/s
For compound 3 the middle estimate is 11-fold (1.03 log units) below the measured one; measured number outside the range, above it.
By their numbers in this assay, from the lowest: compound 1; then compound 2; then compound 3.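

The chain on this oxygen has more room for change than the earlier pair suggested: in this assay, replacing 2-methoxyethoxy with 3-((isopropoxycarbonyl)amino)propoxy gives a 2.2-fold higher number from compound 2 to compound 3 (0.34 log units; beyond the scatter). The entering group has 8 heavy atoms against 2 for the methoxy it replaces, and it brings a hydrogen-bond donor, yet the number goes up, whereas the earlier step of a 12-fold higher number from compound 1 to compound 2 (1.07 log units; beyond the scatter) paired the larger chain with the lower number. Across these two steps, then, group size alone does not set the direction of change in this assay, and no measurement here explains why these two larger groups behave differently.

From the compounds shown here alone, what remains open is which part of the new group goes with the higher number: the longer chain, the nitrogen with its hydrogen, or the isopropoxycarbonyl end. A plain butoxy chain, a 3-aminopropoxy chain with a free amine or a chain ending in a carboxylic acid at this oxygen would help separate these parts, and the compounds shown say nothing about how any of them would read.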